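Bromo in Place of Nitro on Two Related Cores

This account rests on a few compounds, and the source may have more. Where it says the series, first, only, none or still open, it means among the compounds named here.

Compound 1 `CNC(=O)c1cc(Oc2ccc(C3=NNC(c4ccc([N+](=O)[O-])cc4)C3)cc2)ccn1` was tested in a functional assay on HepG2 cells (Homo sapiens) for cytotoxicity, read by MTT assay, with a stated time of 72 h; on this read-out higher numbers stand for weaker inhibition and lower numbers for stronger inhibition. In this assay compound 1 gives only a limit, > 50000 nM. Compound 2 `CNC(=O)c1cc(Oc2ccc(C3=NNC(c4ccc(Br)cc4)C3)cc2)ccn1`, which carries bromo in place of nitro on an aromatic carbon, gives 57600 nM in this assay. The step that the limit leaves unreadable from compound 1 to compound 2 cannot be read in size because of the limit of > 50000 nM in this assay, at which 1 of the 3 values shown sits.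

Compound 3 `CNC(=O)c1cc(Oc2ccc(C3CC(c4ccc([N+](=O)[O-])cc4)=NN3)cc2)ccn1` is built from the same atoms as compound 1, joined differently; the difference between the two cores is not broken down here. In this assay compound 3 gives 28900 nM, a number that sits within the scatter of the value of compound 2.

Compound 4 `CNC(=O)c1cc(Oc2ccc(C3CC(c4ccc(Br)cc4)=NN3)cc2)ccn1` has not yet been measured. Relative to compound 3 it carries the same change, bromo in place of nitro on an aromatic carbon, at the same place, on a six-membered aromatic ring of carbon only, para to a large group. Among the measured compounds shown here, on the first core this change gave a step whose size is hidden by the limit of compound 1, so the only guide is that compound 2 and compound 3 both lie in the same weakly active range. The step is therefore expected to be small, a 1.4-fold higher number from compound 3 to compound 4 (0.14 log units; within the scatter). In this assay compound 4 is expected to give 40000 nM, with the estimate ranging from 15000 nM to 100000 nM.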

Compound 4, half-maximal inhibitory concentration: 16900 nM
For compound 4 the middle estimate is 2.4-fold (0.37 log units) above the measured one; low and high end bracket the measured number.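

On the core of compound 3, the step for bromo in place of nitro on an aromatic carbon in this assay is a 1.7-fold lower number from compound 3 to compound 4 (0.23 log units; within the scatter), so on this core the change from 4-nitrophenyl to 4-bromophenyl shows no difference that can be told apart from the usual variation between repeated measurements. In this assay compound 1 gives only a limit, > 50000 nM, and the step from it to compound 2 on the other core cannot be read in size because of that limit: the limit of > 50000 nM in this assay, at which 1 of the 4 values shown sits. The series therefore offers one readable step and no second one to set beside it, so it shows only what this change does on the core of compound 3 and does not show whether the change carries from one core to the other.

The compounds shown leave open how other groups at this place on the aromatic ring, such as an amine, a carboxylic acid or a longer chain, would read in this assay on either core. They also leave open whether a nitro compound on the core of compound 1 with a value free of any limit would give a step of similar size to the one seen on the core of compound 3.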